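The source may hold more compounds than are shown below. What is called first, only, known or untested is meant among the compounds shown, and "the series" means these compounds.

Compound 1 `COc1ccc(CCOc2ccc(-c3c(C)nc(C)c([C@H](OC(C)(C)C)C(=O)O)c3N3CCC(C)(C)CC3)cc2)cc1` carries a 4-methoxyphenyl group on a saturated chain carbon, two bonds along the chain from an oxygen on an aromatic ring. In an ADME assay on microsomes from liver (Rattus norvegicus) for metabolic stability, read by LC-MS, tested at 0.5 uM (a lower number here means that the compound disappears faster, a higher number that the compound lasts longer), compound 1 gives > 2 h, which is a limit of the assay rather than a number. This is the limit of > 2 h in this assay, at which 2 of the 3 values shown sit, so the standing of compound 1 among the measured compounds is only partly known. Compound 2 `Cc1ccc(CCOc2ccc(-c3c(C)nc(C)c([C@H](OC(C)(C)C)C(=O)O)c3N3CCC(C)(C)CC3)cc2)s1` gives > 2 h in this assay, again only a limit. Compound 3 `Cc1nc(C)c([C@H](OC(C)(C)C)C(=O)O)c(N2CCC(C)(C)CC2)c1-c1ccc(OCCc2cccnc2)cc1` gives 0.783 h in this assay. The step that the two limits leave unreadable from compound 1 to compound 2 thus cannot be sized, whereas the step of an at least 2.5-fold lower number from compound 1 to compound 3 (0.40 log units; beyond the scatter) and the step of an at least 2.5-fold lower number from compound 2 to compound 3 (0.40 log units; beyond the scatter) both show a clear fall.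

Compound 4 `Cc1nc(CCOc2ccc(-c3c(C)nc(C)c([C@H](OC(C)(C)C)C(=O)O)c3N3CCC(C)(C)CC3)cc2)cs1` is still to be measured. It differs from compound 1 in one place: 2-methyl-1,3-thiazol-4-yl in place of 4-methoxyphenyl on a saturated chain carbon, two bonds along the chain from an oxygen on an aromatic ring. The entering group, like the pyridin-3-yl of compound 3, holds nitrogen in its ring, and like the 5-methylthiophen-2-yl of compound 2 it is a five-membered ring containing sulfur. The measured fall from compound 1 to compound 3 suggests a shorter half-life, while the unreadable step to compound 2 gives no direction. A drop of an at least 1.6-fold lower number from compound 1 to compound 4 (0.22 log units; that floor lies within the scatter) is therefore expected. Compound 4 is estimated at 1.2 h, with a range from 0.5 h to 2.5 h.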

Compound 4, half-life: 1.75 h
Beside the measured number, compound 4's estimate is 1.5-fold (0.16 log units) below it; low and high end bracket the measured number.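

In this assay, the step of a 2.2-fold higher number from compound 3 to compound 4 (0.35 log units; beyond the scatter) shows that a nitrogen in the ring at this place on the chain does not fix the half-life, since the two rings holding nitrogen, pyridin-3-yl and 2-methyl-1,3-thiazol-4-yl, give values that differ beyond the scatter. The steps of an at least 1.1-fold lower number from compound 1 to compound 4 (0.05 log units; that floor lies within the scatter) and an at least 1.1-fold lower number from compound 2 to compound 4 (0.05 log units; that floor lies within the scatter) can be read only as floors, so compound 4 may or may not truly lie under the other two. Their real size stays open because compound 1 and compound 2 each rest on a limit of the assay rather than a number: the limit of > 2 h in this assay, at which 2 of the 4 values shown sit.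

The compounds shown do not tell whether the ring itself or its methyl group accounts for the difference from compound 3, and a plain 1,3-thiazol-4-yl or a 6-methylpyridin-3-yl group would help separate the two. They also leave open how far compound 1 and compound 2 outlast compound 4, which only a longer read-out of the half-life could settle.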